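The compounds below may be only part of what the source reports. "The series", "measured", "known", "first", "only" and "open" are said of these compounds alone.

Measured so far:
compound 1, `O=C(Nc1cccc(S(=O)(=O)C2CCCC2)c1)c1cccnc1N1CCCCC1`: > 399 mL.min-1.g-1
compound 2, `CC(C)(C)NS(=O)(=O)c1cccc(NC(=O)c2ccc(NS(C)(=O)=O)cc2N2CCC3(CC2)CC3)c1`: 79 mL.min-1.g-1

Two compounds have been run in an ADME assay on microsomes from liver (Homo sapiens) for metabolic stability, read by LC-MS, with a stated time of 40 min, tested at 0.5 uM; on this read-out higher numbers stand for fast clearance and lower numbers for slow clearance. The result for compound 1 is a limit of the assay rather than a number, > 399 mL.min-1.g-1. Compound 2 gives 79 mL.min-1.g-1 in this assay. Where compound 1 stands is therefore set only by the limit of > 399 mL.min-1.g-1 in this assay, at which 1 of the 2 values shown sits; it sits at the edge of what this assay reports, on the fast-clearance side.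

Compound 3, `O=C(Nc1cccc(S(=O)(=O)C2CCCC2)c1)c1cccnc1N1CCC2(CC1)CC2`, has not yet been measured in this assay. It differs from compound 1 in one place: a group of 8 heavy atoms (7 carbon, 1 nitrogen; one three-membered non-aromatic ring of carbon only, one six-membered non-aromatic ring with 1 hetero atom) in place of a group of 6 heavy atoms (5 carbon, 1 nitrogen; one six-membered non-aromatic ring with 1 hetero atom), on an aromatic carbon.

Going by the values given here, no step between measured compounds shares this change, so nothing here shows its size. The step of an at least 1.1-fold lower number from compound 1 to compound 3 (0.05 log units; that floor lies within the scatter) is expected to stay within the usual scatter, with no move beyond it in either direction. Compound 3 is accordingly estimated at 350 mL.min-1.g-1 in this assay, within a range from 120 mL.min-1.g-1 to 700 mL.min-1.g-1, and it is expected that the assay may again report only a limit.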

Compound 3, intrinsic clearance in microsomes: > 399 mL.min-1.g-1
Compound 3 was reported as a limit; the forecaster's own chance of this, stated with the estimate: 55%; middle value at least 1.1-fold (0.05 log units) from the limit.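

Compound 1 and compound 3 are both reported in this assay only as a limit, so no step between them can be read: the limit of > 399 mL.min-1.g-1 in this assay, at which 2 of the 3 values shown sit.

The compounds shown leave open what clearance either compound actually has, and whether replacing the piperidin-1-yl group changes it at all.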